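The source may report more compounds than this note shows. Statements on the series, on what has been measured and on what is new or still open speak of the compounds shown alone.

Measured in an ADME assay on COS-7 cells (Chlorocebus aethiops) for cytotoxicity, read by MTT assay, with a stated time of 24 h; a higher number here means that more compound is tolerated, a lower number that less compound is tolerated:
- compound 1 `CCOC(=O)c1c(CN2CCCCC2)nc2ccc(Cl)cc2c1-c1ccccc1`: 311000 nM
- compound 2 `CCOC(=O)c1c(CN2CCN(C)CC2)nc2ccc(Cl)cc2c1-c1ccccc1`: 35900 nM
- compound 3 `CCOC(=O)c1c(CN(CC)CC)nc2ccc(Cl)cc2c1-c1ccccc1`: 480000 nM

Compound 3 and compound 1 lie within the scatter of each other, a 1.5-fold higher number from compound 1 to compound 3 (0.19 log units; within the scatter). Compound 2 lies well apart from both, an 8.7-fold lower number from compound 1 to compound 2 (0.94 log units; beyond the scatter) and a 13-fold higher number from compound 2 to compound 3 (1.13 log units; beyond the scatter).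

Compound 4 `CCOC(=O)c1c(CN(C)Cc2ccccc2)nc2ccc(Cl)cc2c1-c1ccccc1` differs from compound 3 on a saturated chain carbon bound to an aromatic carbon: benzyl(methyl)amino in place of diethylamino on a saturated chain carbon bound to an aromatic carbon. All three measured steps change the group at this place, but none brings in an aromatic ring, so they bear only indirectly. Within the data shown here, only the steps involving compound 2 exceed the scatter, so a small move to a lower number is expected. The expected change is a 1.9-fold lower number from compound 3 to compound 4 (0.28 log units; within the scatter), which is not clearly beyond the scatter. For compound 4 the estimated value is 250000 nM, with an expected range of 70000 nM to 600000 nM.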

Compound 4, half-maximal cytotoxic concentration: 315000 nM
Beside the measured number, compound 4's estimate is 1.3-fold (0.10 log units) below it; the range from low to high includes it.
By their numbers in this assay, from the lowest: compound 2; then compounds 1, 4 and 3 (each within the scatter of the next).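

In this assay the step of a 1.5-fold lower number from compound 3 to compound 4 (0.18 log units; within the scatter) and the step of a 1.0-fold higher number from compound 1 to compound 4 (0.01 log units; within the scatter) show that an aromatic ring can enter on this saturated chain carbon without a shift beyond the scatter. The step of an 8.8-fold higher number from compound 2 to compound 4 (0.94 log units; beyond the scatter) leaves the 4-methylpiperazin-1-yl group of compound 2 as the only amine here with a clearly lower number. No available evidence accounts for this pattern.

Open, from the compounds shown here alone, is whether morpholin-4-yl or an unsubstituted piperazin-1-yl at this place would stay with compounds 1, 3 and 4 or with compound 2. A carboxylic acid on the chain is also untested in what is shown here.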